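Methyl for hydrogen on a ring oxygen: expected growth inhibition

A few compounds are considered here, and "the series" means these few. Any claim that something is new, unique, unknown or untested is made for them only; others in the source may bear on it.

Of the compounds shown here, three have been measured in a functional assay on MCF7 cells (Homo sapiens) for inhibition, read by sulforhodamine B assay, with a stated time of 48 h; a lower number here means a stronger inhibitor of growth, a higher number a weaker inhibitor of growth. Compound 1 `CC1(/C=C/c2ccccc2O)C=CC(=O)O1` gives 46200 nM. Compound 2 `CC1(/C=C/c2ccc(O)cc2)C=CC(=O)O1` gives 69100 nM. Compound 3 `COc1ccccc1/C=C/C1(C)C=CC(=O)O1` gives 27000 nM. Compound 1 and compound 2 are built from the same atoms joined differently; the difference between their two cores is not broken down here. Compound 3 arises from compound 1 by methyl in place of hydrogen on an oxygen on an aromatic ring, and this brought a 1.7-fold lower number from compound 1 to compound 3 (0.23 log units; within the scatter). The value of compound 2 stands close to that of compound 1, and the value of compound 3 is the lowest of the three.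

Compound 4 `COc1ccc(/C=C/C2(C)C=CC(=O)O2)cc1` has not yet been measured in this assay. It arises from compound 2 by methyl in place of hydrogen on an oxygen on an aromatic ring, the same change as from compound 1 to compound 3, made at the same kind of place. Because the earlier change gave a 1.7-fold lower number from compound 1 to compound 3 (0.23 log units; within the scatter), a step of similar size is expected here, namely a 1.6-fold lower number from compound 2 to compound 4 (0.22 log units; within the scatter). On that basis compound 4 is estimated at 42000 nM, most likely between 18000 nM and 100000 nM.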

Compound 4, concentration for total growth inhibition: 183000 nM
Estimate against measurement, compound 4: 4.4-fold (0.64 log units) below; measured number outside the range, above it.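

In this assay, replacing hydroxy with methoxy on the core of compound 2 gave a 2.6-fold higher number from compound 2 to compound 4 (0.42 log units; beyond the scatter), a modest step but a real one, so the methyl group did not bring the stronger growth inhibition that the earlier pair had suggested. Set side by side, the two results show that this change cannot be carried from one core to the other as a single fixed step: the same change on two cores in this assay, a 1.7-fold lower number (0.23 log units; within the scatter) from compound 1 to compound 3 and a 2.6-fold higher number (0.42 log units; beyond the scatter) from compound 2 to compound 4, 4.5-fold (0.66 log units) apart, beyond the scatter of two such steps. They do not show why the cores behave differently, and two pairs give no general rule for this series, especially as the step on the core of compound 1 lies within the scatter and so cannot be read as a gain.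

The compounds shown leave open what other groups would do at the same place on each core, such as a longer chain like ethoxy or an amine in place of the hydroxy. From the compounds shown here alone, whether either core would then follow the pattern of compound 4 remains unknown.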